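A few compounds are considered here, and "the series" means these few. Any claim that something is new, unique, unknown or untested is made for them only; others in the source may bear on it.

Three related compounds already have numbers in a functional assay (Cardiac muscle cell, Rattus norvegicus, strain Sprague-Dawley) for inhibition, read by LDH release, with a stated time of 6 h; a higher number here means that more compound is needed for the effect, a lower number that less compound is needed. Compound 1 (`COC(=O)c1oc2ccccc2c1NC(=O)CSc1ccc(OC)cc1`) gives 752 nM, compound 2 (`COC(=O)c1oc2ccccc2c1NC(=O)CSc1ccc([N+](=O)[O-])cc1`) gives 532 nM, and compound 3 (`COC(=O)c1oc2cccc(Cl)c2c1NC(=O)CSc1ccc(Br)cc1`) gives 630 nM. Compound 1 therefore stands level with the other two, since its number cannot be told apart from either of theirs once the usual scatter of repeated measurements is allowed for.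

Compound 4 (`COC(=O)c1oc2ccccc2c1NC(=O)CSc1ccccn1`) has not been measured yet. It keeps the core of compound 1 and changes one group, with pyridin-2-yl in place of 4-methoxyphenyl on a sulfur.

For the measured compounds named here, one measured step bears directly on this. Putting nitro in place of methoxy on an aromatic carbon gave a 1.4-fold lower number from compound 1 to compound 2 (0.15 log units; within the scatter), so that change stayed within the scatter. Going by the values given here, compound 3 differs from compound 1 in more than one place and offers no single step to compare. Among the compounds with values here, no measured compound carries a ring with a hetero atom on the sulfur, so the evidence is thin and the range has to stay wide.

No shift beyond the scatter is expected in this assay. The estimated step is a 1.2-fold lower number from compound 1 to compound 4 (0.08 log units; within the scatter). For compound 4 the expected value is 620 nM, with an estimated range from 250 nM to 1500 nM.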

Compound 4, half-maximal effective concentration: 653 nM
For compound 4 the middle estimate is 1.1-fold (0.02 log units) below the measured one; the range from low to high includes it.
By their numbers in this assay, from the lowest: compounds 2, 3, 4 and 1 (each within the scatter of the next).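

Compounds 1, 2 and 3 all carry a six-membered aromatic ring of carbon only on the sulfur, so they could not show what a hetero atom in that ring does. In this assay, pyridin-2-yl in place of 4-methoxyphenyl gives a 1.2-fold lower number from compound 1 to compound 4 (0.06 log units; within the scatter) and pyridin-2-yl in place of 4-nitrophenyl gives a 1.2-fold higher number from compound 2 to compound 4 (0.09 log units; within the scatter) so neither change moves the number beyond the scatter. At this position, then, the assay cannot tell these three groups apart, and a ring nitrogen is tolerated here, although no data are available to explain this result.

The compounds shown all keep an aromatic ring on the sulfur, so it remains open whether a cyclohexyl ring or a plain butyl chain in that place would hold the number at a similar level. As far as these compounds go, it is also open whether a stronger change would appear with an amine or a carboxylic acid on the ring, or with pyridin-4-yl in place of pyridin-2-yl.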